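From methyl to trifluoromethyl on compound 1

The compounds below may be only part of what the source reports. "The series", "measured", "known", "first", "only" and "open" are said of these compounds alone.

Compound 1 `Cc1ccc(Nc2nccc(-c3ccnc4ccccc34)n2)cc1` gives 600 nM
Compound 2 `Nc1nccc(-c2ccnc3ccccc23)n1` gives 40300 nM

Among the compounds with values here, in a functional assay on MCF7 cells (Homo sapiens) for cytotoxicity, read by sulforhodamine B assay, with a stated time of 48 h (a lower number here means a stronger inhibitor, a higher number a weaker inhibitor), compound 1 gives 600 nM and holds the lower of the two numbers so far. Within the data shown here, the only measured step is a 67-fold higher number from compound 1 to compound 2 (1.83 log units; beyond the scatter) and it is large, well beyond the scatter. That step replaces the whole 4-methylphenyl with hydrogen. Compound 3 `FC(F)(F)c1ccc(Nc2nccc(-c3ccnc4ccccc34)n2)cc1` keeps that ring and differs from compound 1 only by trifluoromethyl in place of methyl on an aromatic carbon at the same spot. The measured step removes far more than this swap does, so it sets no size for it. Expected in this assay is a much smaller change, probably none beyond the scatter, with no direction favoured. The expected step is no change at the digits printed from compound 1 to compound 3 (within the scatter) in this estimate. For compound 3 the estimated value is 600 nM with an expected range (200 nM to 2000 nM).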

Compound 3, half-maximal inhibitory concentration: 1650 nM
Compound 3: the middle estimate sits 2.8-fold (0.44 log units) below what was measured; the measured number falls inside the stated range.
By their numbers in this assay, from the lowest: compound 1; then compound 3; then compound 2.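

In this assay, within the data shown here, the single swap of methyl for trifluoromethyl on the aromatic carbon gives a 2.8-fold higher number from compound 1 to compound 3 (0.44 log units; beyond the scatter), so the exact group at this spot matters, not only the presence of the ring that carries it. Even so, this step is much smaller than a 67-fold higher number from compound 1 to compound 2 (1.83 log units; beyond the scatter), which removes the whole 4-methylphenyl: with the ring kept and only its group changed, most of the activity of compound 1 remains. Nothing measured here explains why the number rises with trifluoromethyl.

With only methyl and trifluoromethyl to compare at this spot, the compounds shown do not tell whether the rise belongs to trifluoromethyl alone or would recur with other groups. A chlorine atom, a methoxy group or an amine at the same spot would help to settle that.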